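The source may report more compounds than this note shows. Statements on the series, on what has been measured and on what is new or still open speak of the compounds shown alone.

Compound 1 `CC(Sc1nnc(-c2ccncc2)s1)C(=O)Nc1ccccc1Cl` carries a 2-chlorophenyl on its amide-type nitrogen and a methyl on the saturated chain carbon bound to a carbonyl carbon and a sulfur. In an ADME assay on HepG2 cells (Homo sapiens) for cytotoxicity, with a stated time of 3 days (on this read-out higher numbers stand for lower toxicity in this test and lower numbers for higher toxicity in this test), compound 1 gives > 50000 nM, which is a limit of the assay rather than a number. Compound 2 `CC(Sc1nnc(-c2ccncc2)s1)C(=O)NCc1ccccc1` differs from it by benzyl in place of 2-chlorophenyl on an amide-type nitrogen. In this assay compound 2 also gives only a limit, > 50000 nM. The step that the two limits leave unreadable from compound 1 to compound 2 therefore cannot be read. Compound 3 `O=C(CSc1nnc(-c2ccncc2)s1)Nc1ccccc1Cl` differs from compound 1 by hydrogen in place of methyl on a saturated chain carbon bound to a carbonyl carbon and a sulfur, and in this assay compound 3 likewise gives a limit, > 50000 nM. The step that the two limits leave unreadable from compound 1 to compound 3 is equally unreadable, since all three values sit at the limit of > 50000 nM in this assay, at which 3 of the 3 values shown sit.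

Compound 4 `O=C(CSc1nnc(-c2ccncc2)s1)NCc1ccccc1` has not yet been measured. It differs from compound 3 by benzyl in place of 2-chlorophenyl on an amide-type nitrogen, which is the same change as that from compound 1 to compound 2, made on the same place. The two cores differ by hydrogen in place of methyl on a saturated chain carbon bound to a carbonyl carbon and a sulfur.

The step that the limit leaves unreadable from compound 3 to compound 4 in this assay is expected to be flat, much as the earlier step that the two limits leave unreadable from compound 1 to compound 2, because both ends of that earlier step rest at the limit of > 50000 nM in this assay, at which 3 of the 3 values shown sit. On this basis compound 4 is estimated at 80000 nM in this assay, with an expected range from 40000 nM to 200000 nM, and most likely it will again return only a limit.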

Compound 4, half-maximal cytotoxic concentration: 17700 nM
Compound 4: the middle estimate sits 4.5-fold (0.66 log units) above what was measured; the whole stated range lies above it.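

In this assay, benzyl in place of 2-chlorophenyl on an amide-type nitrogen gives an at least 2.8-fold lower number from compound 3 to compound 4 (0.45 log units; beyond the scatter), and hydrogen in place of methyl on the saturated chain carbon gives an at least 2.8-fold lower number from compound 2 to compound 4 (0.45 log units; beyond the scatter), which leaves compound 4 as the only compound shown with a number rather than a limit. The benzyl change therefore lowers the number on the core of compound 3, and the true size of that step may be larger than printed, since its starting point is a limit. This does not show whether the change carries over from one core to the other, because the same change on the core of compound 1 cannot be read, and neither can the step from compound 1 to compound 3: the limit of > 50000 nM in this assay, at which 3 of the 4 values shown sit.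

With only this pair of cores, the compounds shown leave open whether the lower number needs benzyl and the chain hydrogen together or would appear with either alone under a less limited read-out. They also leave open how a longer chain such as phenethyl, or an amine or a carboxylic acid on the benzyl ring, would read on the amide-type nitrogen of the core of compound 3.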